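The source may hold more compounds than are shown below. What is called first, only, known or untested is meant among the compounds shown, and "the series" means these compounds.

Compound 2 `CN(C)CCCNc1ccnc2cc(OCc3ccc(F)cc3)ccc12` gives 1570 nM in a functional assay on HepG2 cells (Homo sapiens) for cytotoxicity, read by MTT assay, with a stated time of 48 h (on this read-out lower numbers stand for stronger inhibition and higher numbers for weaker inhibition), the lowest of the three numbers recorded there, though its neighbours sit close: compound 1 `CC(C)COc1ccc2c(Cl)ccnc2c1` gives 2250 nM and compound 3 `Fc1ccc(COc2ccc3c(Cl)ccnc3c2)cc1` gives 3010 nM. For the measured compounds named here, the only single-point step among the measured compounds is a 1.9-fold higher number from compound 2 to compound 3 (0.28 log units; within the scatter), which exchanges the aminoalkyl chain for a chloro group and leaves the number essentially where it was.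

Compound 4 `CCOc1ccc2c(NCCCN(C)C)ccnc2c1` has not been measured. It departs from compound 2 at the ether side of the shared core: methyl in place of 4-fluorophenyl on a saturated chain carbon bound to an oxygen on an aromatic ring, a change that, read one bond further out, amounts to 4-fluorobenzyl becoming ethyl. Going by the values given here, no measured step touches this part of the molecule directly. The closest guide is the pair of compound 1 and compound 3, which carry an isobutyl and a 4-fluorobenzyl ether on otherwise identical cores; compound 1 gives 2250 nM and compound 3 gives 3010 nM, and the two show little separation. With so thin a basis, the expected step of a 1.3-fold higher number from compound 2 to compound 4 (0.11 log units; within the scatter) is none beyond the scatter. Compound 4 is therefore estimated at 2000 nM in this assay, with a range from 900 nM to 4500 nM.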

Compound 4, half-maximal inhibitory concentration: 5860 nM
The estimate for compound 4 lay 2.9-fold (0.47 log units) below the measured number; the whole stated range lies below it.
By their numbers in this assay, from the lowest: compounds 2, 1, 3 and 4 (each within the scatter of the next, the first and the last beyond it).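

For the compounds shown here, the ether side of the shared core, which no earlier single-point step had touched, now has a step of its own: with the (3-(dimethylamino)propyl)amino chain held in place, going from 4-fluorobenzyl to ethyl gives a 3.7-fold higher number from compound 2 to compound 4 (0.57 log units; beyond the scatter) in this assay. Going by these compounds alone, this modest change is the only single-point step here to pass beyond the scatter, whereas the exchange of the aminoalkyl chain for chloro gave a 1.9-fold higher number from compound 2 to compound 3 (0.28 log units; within the scatter). So, in this pair, the group on the saturated chain carbon bound to the oxygen on the aromatic ring has a readable effect on the number, although nothing presented here gives any reason for the shift.

The compounds shown leave open whether the higher number follows the loss of the whole 4-fluorophenyl ring or only of its fluorine, which a plain benzyl ether would separate, and whether a longer chain such as hexyl in place of ethyl would behave like the ring. They also leave open whether the same exchange would give a similar step on the core that carries chloro instead of the aminoalkyl chain.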